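From tert-butylphenyl to pyridine on a sulfonyl

This account rests on a few compounds, and the source may have more. Where it says the series, first, only, none or still open, it means among the compounds named here.

In a functional assay on MDA-MB-231 cells (Homo sapiens) for antiproliferative activity, read by MTT assay, with a stated time of 24 h (a higher number here means a weaker inhibitor, a lower number a stronger inhibitor), compound 1 `O=C(c1cc(Cl)ccn1)N1CCN(c2nccc(Oc3cc(Cl)cc(Cl)c3)n2)CC1` gives 16700 nM. Compound 2 `O=C([C@H]1Cc2ccccc2N1)N1CCN(c2nccc(Oc3cc(Cl)cc(Cl)c3)n2)CC1` gives > 50000 nM, which is a limit of the assay. Compound 3 `CC(C)(C)c1ccc(S(=O)(=O)N2CCN(c3nccc(Oc4cc(Cl)cc(Cl)c4)n3)CC2)cc1` gives > 50000 nM, also a limit and not a number. That is the limit of > 50000 nM in this assay, at which 2 of the 3 values shown sit. Compound 4 `O=S(=O)(c1cccnc1)N1CCN(c2nccc(Oc3cc(Cl)cc(Cl)c3)n2)CC1` differs from compound 3 as follows: pyridin-3-yl in place of 4-(tert-butyl)phenyl on a sulfonyl sulfur. Among the measured compounds shown here, the only measured step, an at least 2.9-fold higher number from compound 1 to compound 2 (0.47 log units; beyond the scatter), took place on a carbonyl carbon, so it bears on this change only indirectly. For the measured compounds named here, compound 1, the only compound with a number, carries a 4-chloropyridin-2-yl group, which gives some reason to expect a modest gain from a pyridine ring. The expected size is an at least 1.4-fold lower number from compound 3 to compound 4 (0.15 log units; that floor lies within the scatter), towards a lower number. Compound 4 is estimated at 35000 nM, with an expected range of 12000 nM to 60000 nM.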

Compound 4, half-maximal inhibitory concentration: 24800 nM
Compound 4: middle estimate off by 1.4-fold (0.15 log units), on the high side; measured number inside the range.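

On the sulfonyl sulfur, pyridin-3-yl gives a number in this assay where 4-(tert-butyl)phenyl did not, with an at least 2.0-fold lower number from compound 3 to compound 4 (0.30 log units; that floor lies within the scatter). Going by these compounds, the true size of this step stays unknown because the value of compound 3 is a limit: the limit of > 50000 nM in this assay, at which 2 of the 4 values shown sit. Putting (pyridin-3-yl)sulfonyl in place of (4-chloropyridin-2-yl)carbonyl on the amine nitrogen in a ring gives a 1.5-fold higher number from compound 1 to compound 4 (0.17 log units; within the scatter), so the two linked pyridine rings hold level.

On these data alone, whether an amine or a carboxylic acid on the pyridin-3-yl ring would change the number remains open. So does the outcome for an unsubstituted phenyl ring on the sulfonyl sulfur.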